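Carboxy to hydroxymethyl on the ether chain of compound 3

This account rests on a few compounds, and the source may have more. Where it says the series, first, only, none or still open, it means among the compounds named here.

In a functional assay on HEK293 cells for agonist activity at Bile acid receptor (Homo sapiens), read by a luciferase reporter (on this read-out lower numbers stand for an effect already at smaller amounts and higher numbers for an effect only at larger amounts of compound), compound 3 `CC(C)c1onc(-c2c(Cl)cccc2Cl)c1COc1ccc(N(C)Cc2ccc(OCC(=O)O)cc2)c(C(F)(F)F)n1` gives 19 nM, the second highest of the three numbers; compound 2 `CC(C)c1onc(-c2c(Cl)cccc2Cl)c1COc1ccc(N(C)Cc2ccc(CCC(=O)O)cc2)c(C(F)(F)F)n1` gives 16 nM and compound 1 `CC(C)c1onc(-c2c(Cl)cccc2Cl)c1COc1ccc(N(C)C(=O)c2ccc(C(=O)O)cc2)c(C(F)(F)F)n1` gives 208 nM. The large steps of a 13-fold lower number from compound 1 to compound 2 (1.11 log units; beyond the scatter) and an 11-fold lower number from compound 1 to compound 3 (1.04 log units; beyond the scatter) concern the group on the ring nitrogen, not the carboxy group itself, while the step of a 1.2-fold higher number from compound 2 to compound 3 (0.07 log units; within the scatter) shows the two carboxy-bearing chains matching within the scatter. Compound 4 `CC(C)c1onc(-c2c(Cl)cccc2Cl)c1COc1ccc(N(C)Cc2ccc(OCCO)cc2)c(C(F)(F)F)n1` carries hydroxymethyl in place of carboxy on a saturated chain carbon bound to an oxygen on an aromatic ring. Going by the values given here, no measured pair removes the carboxy group, so nothing here bears directly on this change; the comparison between compound 2 and compound 3 only shows that the chain at this position can vary. Among the compounds with values here, the expected step of a 2.4-fold higher number from compound 3 to compound 4 (0.37 log units; beyond the scatter) therefore rests on no direct precedent and carries a wide range. Compound 4 is estimated at 45 nM, within 8 nM to 250 nM.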

Compound 4, half-maximal effective concentration: 155 nM
Compound 4: the middle estimate sits 3.4-fold (0.54 log units) below what was measured; low and high end bracket the measured number.
By their numbers in this assay, from the lowest: compounds 2 and 3 (each within the scatter of the next); then compounds 4 and 1 (each within the scatter of the next).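

Removing the carboxy group does matter here: hydroxymethyl in place of carboxy gives an 8.2-fold higher number from compound 3 to compound 4 (0.91 log units; beyond the scatter) in this assay, and against the other carboxy-bearing chain, 2-hydroxyethoxy in place of 2-carboxyethyl gives a 9.7-fold higher number from compound 2 to compound 4 (0.99 log units; beyond the scatter). So the position that accepted either carboxy-bearing chain accepts this neutral replacement far less well, and the gain from the benzyl linkage disappears, with a 1.3-fold lower number from compound 1 to compound 4 (0.13 log units; within the scatter) leaving compound 4 level with the carbonyl-linked acid. Nothing measured here explains this loss. Open, as far as these compounds go, is whether a tetrazole or an acylsulfonamide on the same chain would hold the numbers of compound 2 and compound 3. Also open, from the compounds shown here alone, is how a longer chain ending in a carboxylic acid would read.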